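Replacing a silyl group by acetyl in a diterpenoid series

This account rests on a few compounds, and the source may have more. Where it says the series, first, only, none or still open, it means among the compounds named here.

Three related compounds have been tested in a functional assay on Col2 cells (Homo sapiens) for cytotoxicity, read by sulforhodamine B assay; on this read-out lower numbers stand for an effect already at smaller amounts and higher numbers for an effect only at larger amounts of compound. Compound 1 `C=C1CC[C@@H]2[C@](C)(COC(C)=O)[C@H](OC(C)=O)CC[C@@]2(C)[C@@H]1C/C=C1/C(=O)OC[C@H]1OC(C)=O` gives 10.8 uM in this assay. Compound 2 `C=C1CC[C@@H]2[C@](C)(CO[Si](C(C)C)(C(C)C)C(C)C)[C@H](OC(C)=O)CC[C@@]2(C)[C@@H]1C/C=C1/C(=O)OC[C@H]1OC(C)=O` gives 13.6 uM. Compound 3 `C=C1CC[C@@H]2[C@](C)(CO[Si](C(C)C)(C(C)C)C(C)C)[C@H](O)CC[C@@]2(C)[C@@H]1C/C=C1/C(=O)OC[C@H]1O` gives 2.73 uM, the lowest of the three numbers, and its distance to compound 1 and to compound 2 lies beyond the usual scatter.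

Compound 2 and compound 1 differ in one place only: a group of 3 heavy atoms (2 carbon, 1 oxygen; no ring) in place of a group of 10 heavy atoms (9 carbon, 1 silicon; no ring), on an oxygen on a saturated carbon. This change gave a 1.3-fold lower number from compound 2 to compound 1 (0.10 log units; within the scatter), so the exchange of the bulky silicon-containing group for the small acetyl group left the read-out essentially unchanged.

Compound 3 carries the same silicon-containing group as compound 2, but the two differ elsewhere as well, and the difference between the two cores is not broken down here.

Compound 4 `C=C1CC[C@@H]2[C@](C)(COC(C)=O)[C@H](O)CC[C@@]2(C)[C@@H]1C/C=C1/C(=O)OC[C@H]1O` has not yet been measured. It arises from compound 3 by a group of 3 heavy atoms (2 carbon, 1 oxygen; no ring) in place of a group of 10 heavy atoms (9 carbon, 1 silicon; no ring), on an oxygen on a saturated carbon, the same change that turns compound 2 into compound 1, at the same place. Because a 1.3-fold lower number from compound 2 to compound 1 (0.10 log units; within the scatter) was small, the expected step of a 1.2-fold lower number from compound 3 to compound 4 (0.07 log units; within the scatter) from compound 3 to compound 4 is also expected to stay within the scatter. Among the measured compounds shown here, compound 4 is therefore estimated at 2.3 uM in this assay, with a range from 1.1 uM to 5 uM, since the only comparable step rests on a single pair of measured compounds.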

Compound 4, concentration for half-maximal effect: 12.9 uM
Compound 4: the middle estimate sits 5.6-fold (0.75 log units) below what was measured; measured number outside the range, above it.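

In this assay, exchanging the silicon-containing group for acetyl on the same oxygen gave a 4.7-fold higher number from compound 3 to compound 4 (0.67 log units; beyond the scatter), so a change that left the read-out essentially unchanged on the core of compound 2 had a clear effect on the core of compound 3. Among the compounds shown here, this change therefore cannot be carried from one core to another as a fixed step, and a small step on one core says little about its size on the other: the same change on two cores in this assay, a 1.3-fold lower number (0.10 log units; within the scatter) from compound 2 to compound 1 and a 4.7-fold higher number (0.67 log units; beyond the scatter) from compound 3 to compound 4, 6.0-fold (0.77 log units) apart, beyond the scatter of two such steps This does not show which structural difference between the two cores accounts for the gap, or why the step depends on the core, and each core is represented by only one pair of compounds, so two steps cannot establish a general rule for the series.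

The compounds shown leave open how a free hydroxyl, a methyl ether or a longer acyl chain such as butyryl on that same oxygen would behave on each core. They also leave open which core would show the larger step with such groups, and whether a core carrying acetyl at only one of the two other oxygens would behave like the core of compound 2 or that of compound 3.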